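Restoring a fused aromatic amine: expected cytotoxicity of compound 3

The source may hold more compounds than are shown below. What is called first, only, known or untested is meant among the compounds shown, and "the series" means these compounds.

Compound 1 `COc1ccc2[nH]c(C(=O)N3CC(=O)N(Cc4ccccc4)[C@@H](N4CCc5ccccc54)C3)cc2c1`: > 100000 nM
Compound 2 `COc1ccc2[nH]c(C(=O)N3CC(=O)N(Cc4ccccc4)[C@@H](CN4CC5(CCC5)C4)C3)cc2c1`: 52700 nM

For the measured compounds named here, in an ADME assay on Vero cells (Chlorocebus sabaeus) for cytotoxicity, with a stated time of 7 days (on this read-out lower numbers stand for higher toxicity in this test and higher numbers for lower toxicity in this test), compound 2 gives 52700 nM, the only plain number among the two results in hand. For compound 1 the result is a limit of the assay, > 100000 nM. Compound 3 `COc1ccc2[nH]c(C(=O)N3CC(=O)N(Cc4ccccc4)[C@@H](CN4CCCc5ccccc54)C3)cc2c1` differs from compound 2 by a group of 10 heavy atoms (9 carbon, 1 nitrogen; one six-membered non-aromatic ring with 1 hetero atom, one six-membered aromatic ring of carbon only) in place of a group of 7 heavy atoms (6 carbon, 1 nitrogen; one four-membered non-aromatic ring of carbon only, one four-membered non-aromatic ring with 1 hetero atom), on a saturated chain carbon bound to a saturated ring carbon. Going by the values given here, the single measured step, an at least 1.8-fold lower number from compound 1 to compound 2 (0.27 log units; that floor lies within the scatter), is of the opposite kind, a fused aromatic amine giving way to a spiro-amine, and its size is only a floor that falls inside the scatter, so no clear change was seen. Compound 1 itself sits at the limit of > 100000 nM in this assay, at which 1 of the 2 values shown sits. Bringing a fused aromatic amine back in compound 3 is therefore expected to leave the number about where compound 2 stands or somewhat higher, a step of a 1.5-fold higher number from compound 2 to compound 3 (0.18 log units; within the scatter), with a real chance that only a limit is reported again. Compound 3 is estimated at 80000 nM, between 35000 nM and 150000 nM.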

Compound 3, half-maximal cytotoxic concentration: > 100000 nM
Compound 3: only a limit was reported; the forecaster's own chance of this, stated with the estimate: 40%; middle value at least 1.2-fold (0.09 log units) away from the limit.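

On the saturated chain carbon bound to a saturated ring carbon, 1,2,3,4-tetrahydroquinolin-1-yl in place of the group with two four-membered rings gives an at least 1.8-fold higher number from compound 2 to compound 3 (0.27 log units; that floor lies within the scatter) in this assay. For the compounds shown here, this is the first sign that the number can move upward at this place, though it is no clear change. Compound 3 is reported only as a limit, as is compound 1, so the step between these two cannot be read, and both compounds that carry a fused aromatic amine now give this result: the limit of > 100000 nM in this assay, at which 2 of the 3 values shown sit.

Going by these compounds, how far the true values of compound 1 and compound 3 lie from that limit remains unknown. On these data alone, it also remains open whether a non-fused amine such as piperidin-1-yl or morpholin-4-yl at the same place would give a plain number like that of compound 2.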